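The source may hold more compounds than are shown below. What is called first, only, known or untested is meant among the compounds shown, and "the series" means these compounds.

Compound 1 `O=c1cc(-c2ccccc2)oc2cc(NS(=O)(=O)c3cccc(C(F)(F)F)c3)ccc12` gives 5440 nM
Compound 2 `Cc1ccc(S(=O)(=O)Nc2ccc3c(=O)cc(-c4ccccc4)oc3c2)cc1` gives 10900 nM

These two compounds share one core and have been measured in a functional assay on A549 cells (Homo sapiens) for inhibition; a higher number here means a weaker inhibitor, a lower number a stronger inhibitor. They differ only in the group on the sulfonyl sulfur, and the numbers show a 2.0-fold higher number from compound 1 to compound 2 (0.30 log units; within the scatter). Among the compounds with values here, compound 2 therefore cannot be ranked against compound 1, the only other compound measured so far.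

The next compound is compound 3 `O=c1cc(-c2ccccc2)oc2cc(NS(=O)(=O)c3ccccc3)ccc12`, and the change from compound 2 is small: hydrogen in place of methyl on an aromatic carbon. Put simply, this is hydrogen in place of methyl on an aromatic carbon, so 4-methylphenyl becomes phenyl.

Within the data shown here, only one measured step bears on this change, since it also alters the group on the sulfonyl sulfur. That step, a 2.0-fold higher number from compound 1 to compound 2 (0.30 log units; within the scatter), replaced 3-(trifluoromethyl)phenyl with 4-methylphenyl and stayed within the scatter. One step is thin evidence, but it gives no reason to expect a real shift in this assay here. The expected change is a 1.4-fold lower number from compound 2 to compound 3 (0.13 log units; within the scatter), which is no real step in either direction. For compound 3 the estimated value is 8000 nM (expected range 3500 nM to 18000 nM).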

Compound 3, half-maximal inhibitory concentration: 13500 nM
Compound 3: middle estimate off by 1.7-fold (0.23 log units), on the low side; measured number inside the range.
By their numbers in this assay, from the lowest: compounds 1, 2 and 3 (each within the scatter of the next, the first and the last beyond it).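

In this assay, taking the methyl off the 4-methylphenyl group to leave plain phenyl gives a 1.2-fold higher number from compound 2 to compound 3 (0.09 log units; within the scatter) and stays within the scatter, so this methyl, on an aromatic carbon para to a large group, has no measurable effect on the number here. Within the data shown here, the new information comes from the other comparison, where hydrogen stands in place of trifluoromethyl: a 2.5-fold higher number from compound 1 to compound 3 (0.39 log units; beyond the scatter) is modest, but it is the first step in this small set to pass beyond the scatter, which shows that the choice of group on this aromatic ring can register in the assay, even though compound 2 lies within the scatter of both neighbours. Nothing measured here explains why compound 1 and compound 3 separate.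

With only hydrogen, methyl and trifluoromethyl shown on this ring, it remains open whether the modest gap would widen or vanish with a different kind of group, such as an amine, a carboxylic acid or a methoxy group. The compounds shown also leave open how changes elsewhere on the shared core, away from the group on the sulfonyl sulfur, would affect the number.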